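A few compounds are considered here, and "the series" means these few. Any claim that something is new, unique, unknown or untested is made for them only; others in the source may bear on it.

Working notes on the series.

Three compounds share one core and differ only in the group on a saturated chain carbon bound to a saturated ring carbon. In an assay on isolated protein for displacement of a labelled ligand from 5-hydroxytryptamine receptor 6 (Homo sapiens) (on this read-out higher numbers stand for weaker inhibition and lower numbers for stronger inhibition), compound 1 `CN(C[C@@H]1CCCc2cc(S(=O)(=O)c3cccc(F)c3)ccc21)S(N)(=O)=O` gives 3.98 nM. Compound 2 `CNS(=O)(=O)NC[C@@H]1CCCc2cc(S(=O)(=O)c3cccc(F)c3)ccc21` gives 1 nM in this assay, the step being a 4.0-fold lower number from compound 1 to compound 2 (0.60 log units; beyond the scatter). Compound 3 `O=S(=O)(c1cccc(F)c1)c1ccc2c(c1)CCC[C@H]2CN1CCCS1(=O)=O` gives 31.6 nM in this assay, the highest of the three numbers: a 7.9-fold higher number from compound 1 to compound 3 (0.90 log units; beyond the scatter) and a 32-fold higher number from compound 2 to compound 3 (1.50 log units; beyond the scatter). The open-chain sulfamides thus sit well below the ring sulfonamide, and the one with a hydrogen on the chain nitrogen, compound 2, sits lowest.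

Compound 4 `O=C(NC[C@@H]1CCCc2cc(S(=O)(=O)c3cccc(F)c3)ccc21)c1ccc[nH]1` is not yet measured. It differs from compound 3 by a group of 8 heavy atoms (5 carbon, 2 nitrogen, 1 oxygen; one five-membered aromatic ring with 1 hetero atom) in place of a group of 7 heavy atoms (3 carbon, 1 nitrogen, 2 oxygen, 1 sulfur; one five-membered non-aromatic ring with 2 hetero atoms), on a saturated chain carbon bound to a saturated ring carbon. Among the measured compounds shown here, no measured step covers a carbonyl amide here, so the expectation rests on the two steps away from compound 3. Both of those steps show that leaving the ring sulfonamide for a group carrying a hydrogen on nitrogen lowers the number by a modest to large amount, and the entering group again brings hydrogen-bond donors. A modest step downward in this assay is therefore expected, roughly a 5.3-fold lower number from compound 3 to compound 4 (0.72 log units; beyond the scatter), with real uncertainty since the new group is not a sulfonamide at all.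

For compound 4 the expected value in this assay is 6 nM, with a range of 1.5 nM to 25 nM.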

Compound 4, inhibition constant: 5.01 nM
Compound 4: the middle estimate sits 1.2-fold (0.08 log units) above what was measured; low and high end bracket the measured number.
By their numbers in this assay, from the lowest: compound 2; then compounds 1 and 4 (each within the scatter of the next); then compound 3.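

In this assay, the ((1H-pyrrol-2-yl)carbonyl)amino group shows that a low number at this place does not depend on a sulfamide, with a 6.3-fold lower number from compound 3 to compound 4 (0.80 log units; beyond the scatter) for a group that holds no sulfur at all. Its number stands level with that of the methyl(sulfamoyl)amino group, a 1.3-fold higher number from compound 1 to compound 4 (0.10 log units; within the scatter), while the (methylsulfamoyl)amino group still gives the lowest number of the series, a 5.0-fold higher number from compound 2 to compound 4 (0.70 log units; beyond the scatter), so a carbonyl amide matches one open-chain sulfamide but not the other. Nothing available accounts for this ranking of the groups.

Open, on these data alone, is whether the 1H-pyrrol-2-yl ring itself matters to the number, or whether a phenyl ring or a plain methyl on the same carbonyl would give a similar value in this assay. Also open, as far as these compounds go, is how a free amine or a carboxylic acid on the saturated chain carbon would compare with these groups, and so whether a sulfamide or carbonyl amide is needed at this place at all.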